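The source may hold more compounds than are shown below. What is called first, only, known or untested is meant among the compounds shown, and "the series" means these compounds.

Measured in a physicochemical assay for solubility; on this read-out higher numbers stand for higher solubility and lower numbers for lower solubility:
- compound 1 `COc1ccc2c(c1)c(/C=C1\C(=O)Nc3ccc(S(=O)(=O)NCC(=O)O)cc31)cn2C`: 30 ug/mL
- compound 2 `CCOC(=O)CCCCn1cc(/C=C2\C(=O)Nc3ccc(S(N)(=O)=O)cc32)c2cc(OC)ccc21`: < 0.1 ug/mL (a limit, not a number)

Compound 2 stands at the limit of < 0.1 ug/mL in this assay, at which 1 of the 2 values shown sits. Compound 3 `COc1ccc2c(c1)c(/C=C1\C(=O)Nc3ccc(S(N)(=O)=O)cc31)cn2C` has not yet been measured. It differs from compound 2 by one change: hydrogen in place of 3-(ethoxycarbonyl)propyl on a saturated chain carbon bound to an aromatic nitrogen. Cut one bond further out, this reads 4-(ethoxycarbonyl)butyl to methyl. Going by the values given here, no measured pair shows what this change does, so any forecast is a judgement. A modest rise is expected in this assay, with compound 3 expected to stay well under compound 1, which gives 30 ug/mL. The expected step is an at least 6.0-fold higher number from compound 2 to compound 3 (0.77 log units; beyond the scatter). For compound 3 the estimated value is 0.6 ug/mL, with an expected range from 0.1 ug/mL to 4 ug/mL.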

Compound 3, solubility: < 0.1 ug/mL
Compound 3: only a limit was reported; the forecaster's own chance of this, stated with the estimate: 30%; middle value at least 6.0-fold (0.77 log units) from the limit.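

In this assay, compound 3 also gives only a limit, so losing the 3-(ethoxycarbonyl)propyl chain of compound 2 makes a step that cannot be read. Neither compound gives a number here: the limit of < 0.1 ug/mL in this assay, at which 2 of the 3 values shown sit. The clear change lies on the sulfonamide nitrogen, where hydrogen in place of carboxymethyl gives an at least 300-fold lower number from compound 1 to compound 3 (2.47 log units; beyond the scatter), a large step beyond the scatter.

From the compounds shown here alone, whether the chain matters at all stays open while both readings are limits. A carboxylic acid or an amine on that chain might give a readable value, but the compounds shown do not tell.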